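The compounds below may be only part of what the source reports. "The series", "measured", "known", "first", "only" and "open" are said of these compounds alone.

Three compounds share one core, a five-membered non-aromatic ring with one nitrogen and one sulfur attached to a fused bicyclic lactam, and differ only in the group on a saturated ring carbon. Compound 1 `COc1cc(C2SCC(=O)N2c2ccc3c(C)cc(=O)[nH]c3c2)ccc1O` gives 12.4% in a functional assay on the whole organism (strain albino) for inhibition, with Rattus norvegicus as the target, read by paw edema, with stated times of 1 h and 3 h, at a dose of 100 mg/kg by the oral route; on this read-out higher numbers stand for more inhibition at the one dose given (going by the name of the read-out) and lower numbers for less inhibition. Compound 2 `Cc1cc(=O)[nH]c2cc(N3C(=O)CSC3c3ccc([N+](=O)[O-])cc3)ccc12` gives 25.2%. Compound 3 `Cc1cc(=O)[nH]c2cc(N3C(=O)CSC3N3CCCCC3)ccc12`, carrying a piperidin-1-yl group at that position, gives 2.77%, the lowest of the three numbers: the gap to compound 1 is within the scatter, while the gap to compound 2 is beyond it.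

Compound 4 `Cc1cc(=O)[nH]c2cc(N3C(=O)CSC3/C=C/c3ccccc3)ccc12` has not been measured. Its change from compound 3 is 2-phenylethenyl in place of piperidin-1-yl on a saturated ring carbon.

For the measured compounds named here, two measured steps bear on this. Going from an aromatic group to piperidin-1-yl lowered the number in both cases: a number 9.6 percentage points lower from compound 1 to compound 3 (within the scatter) and a number 22.4 percentage points lower from compound 2 to compound 3 (beyond the scatter). Going by the values given here, compound 4 reverses that kind of change, so a rise of modest size is expected, though no measured compound carries a 2-phenylethenyl group. For compound 4 the estimate is 15%, between 3% and 30%, which means an expected step of a number 12.2 percentage points higher from compound 3 to compound 4 (beyond the scatter).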

Compound 4, a percentage reported as inhibition, in the whole organism at one dose (the size of the read-out at that dose, not a potency): 20.8%
Estimate against measurement, compound 4: 5.8 percentage points below; the measured number falls inside the stated range.
By their numbers in this assay, from the lowest: compounds 3, 1, 4 and 2 (each within the scatter of the next, the first and the last beyond it).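

In this assay the position also takes an aromatic ring held on a double bond rather than joined directly to the saturated ring carbon: there is a number 18 percentage points higher from compound 3 to compound 4 (beyond the scatter) and this places the new group clearly apart from piperidin-1-yl. The two directly joined aromatic groups cannot be told apart from it, with a number 4.4 percentage points lower from compound 2 to compound 4 (within the scatter) and a number 8.4 percentage points higher from compound 1 to compound 4 (within the scatter) so neither the nitro group nor the hydroxy and methoxy groups are needed to reach this range, and 2-phenylethenyl itself has no hydrogen-bond donors or acceptors. Nothing available explains why the number moves with this change.

A 2-phenylethyl group or an unsubstituted phenyl group would show whether the double bond itself matters. A morpholine in place of piperidin-1-yl, or a carboxylic acid on the phenyl ring of 2-phenylethenyl, would test how far these trends extend.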